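The source may report more compounds than this note shows. Statements on the series, on what has been measured and on what is new or still open speak of the compounds shown alone.

In an ADME assay on microsomes from liver (Rattus norvegicus, strain Crj;CD(SD)) for metabolic stability, read by LC-MS, using NADPH, with a stated time of 30 min, tested at 0.1 uM (on this read-out lower numbers stand for a less stable compound and higher numbers for a more stable compound), compound 1 `C[C@@]1(c2cc(NC(=O)c3cnc(OCF)cn3)ccc2F)C=C(CF)OC(N)=N1` gives 52% and compound 2 `C[C@@]1(c2cc(NC(=O)c3coc(C(F)F)n3)ccc2F)C=C(CF)OC(N)=N1` gives 57%, so the two stand within the usual scatter of each other. Compound 3 `C[C@@]1(c2cc(NC(=O)c3ncc(OCF)nc3N)ccc2F)C=C(CF)OC(N)=N1` differs from compound 1 in one place: amino in place of hydrogen on an aromatic carbon. Among the measured compounds shown here, the only measured step, a number 5 percentage points higher from compound 1 to compound 2 (within the scatter), replaces the whole group on the carbonyl carbon, so it bears on this change only loosely, and no measured step introduces an amino group. No shift beyond the scatter is therefore expected, and the estimated step is a number 2 percentage points lower from compound 1 to compound 3 (within the scatter). Compound 3 is expected at 50%, with an estimated range of 33% to 67%.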

Compound 3, percent of the compound remaining: 35%
Beside the measured number, compound 3's estimate is 15 percentage points above it; measured number inside the range.
By their numbers in this assay, from the lowest: compound 3; then compounds 1 and 2 (each within the scatter of the next).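

In this assay, among the compounds shown here, amino on this aromatic carbon, next to the ring nitrogen, gives a number 17 percentage points lower from compound 1 to compound 3 (beyond the scatter), the first change here that moves the read-out beyond the scatter. Exchanging the whole group on the carbonyl carbon for 3-amino-5-(fluoromethoxy)pyrazin-2-yl likewise gives a number 22 percentage points lower from compound 2 to compound 3 (beyond the scatter), so compound 3 stands apart from both earlier compounds. Nothing available explains this drop. Going by these compounds, whether it is particular to amino remains open, since a hydroxyl or methylamino group on the same carbon would test that. Also open, on these data alone, is whether amino would act alike on another ring.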